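This account rests on a few compounds, and the source may have more. Where it says the series, first, only, none or still open, it means among the compounds named here.

Compound 1 `COc1ccc(/C=C/C(=O)Nc2cc3c(Nc4ccc(F)c(Cl)c4)ncnc3cc2OC)c(OC)c1` shares its core with compound 2 `COc1ccc(OC)c(/C=C/C(=O)Nc2cc3c(Nc4ccc(F)c(Cl)c4)ncnc3cc2O[C@H]2CCOC2)c1` and compound 3 `COc1cc(/C=C/C(=O)Nc2cc3c(Nc4ccc(F)c(Cl)c4)ncnc3cc2O[C@H]2CCOC2)cc(OC)c1O`, the three differing only in the aryl group on the double-bonded chain carbon and in the ether at the core. In a functional assay on PC-3 cells (Homo sapiens) for cytotoxicity, read by MTT assay, with a stated time of 72 h (on this read-out lower numbers stand for stronger inhibition and higher numbers for weaker inhibition), compound 1 gives 38500 nM, the highest of the three numbers; compound 2 gives 8730 nM and compound 3 gives 26500 nM. Among the compounds with values here, the one measured step at the aryl position, a 3.0-fold higher number from compound 2 to compound 3 (0.48 log units; beyond the scatter), shows that a change of the aryl substitution pattern can move this assay modestly. Compound 4 `COc1cc2ncnc(Nc3ccc(F)c(Cl)c3)c2cc1NC(=O)/C=C/c1ccc(C#N)cc1` is the next compound, carrying the change (4-cyanophenyl in place of 2,4-dimethoxyphenyl on a double-bonded chain carbon bound to a double-bonded chain carbon). Within the data shown here, no measured pair tests a cyano group here, so the step from compound 2 to compound 3 is the only guide, and it points to a modest shift at most. Compound 4 is therefore expected to show a 1.5-fold lower number from compound 1 to compound 4 (0.19 log units; within the scatter), a shift of uncertain direction. The estimate for compound 4 in this assay is 25000 nM, with a range from 8000 nM to 80000 nM.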

Compound 4, half-maximal inhibitory concentration: "not active" (no number reported)
For compound 4 the study gives words and no number; there is nothing to compare the estimate with.
By their numbers in this assay, from the lowest: compound 2; then compounds 3 and 1 (each within the scatter of the next).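

Within the data shown here, compound 4 is reported in this assay only in words, as not active, so no step from compound 1 to compound 4 can be read. Nothing measured here offers an explanation for this result. What the compounds shown leave open is how 4-cyanophenyl in place of 2,4-dimethoxyphenyl shifts the number.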